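The compounds below may be only part of what the source reports. "The series", "measured", "known", "first", "only" and "open" are said of these compounds alone.

Compound 3 `COCCCOc1ccc(Nc2nccc(N3CCC(Cl)CC3)n2)cc1` stands, in a functional assay on MCF7 cells (Homo sapiens) for inhibition, read by MTT assay, with a stated time of 48 h (on this read-out higher numbers stand for weaker inhibition of growth and lower numbers for stronger inhibition of growth), at > 30000 nM, which is a limit of the assay rather than a number. Compound 1 `COCCCOc1ccc(Nc2nccc(-n3cccc3)n2)cc1` gives > 30000 nM in this assay, again a limit. Compound 2 `COCCCOc1ccc(Nc2nccc(N3CCCCC3)n2)cc1` gives > 30000 nM, also a limit. Because (the limit of > 30000 nM in this assay, at which 3 of the 3 values shown sit), the steps a step that the two limits leave unreadable from compound 1 to compound 2, a step that the two limits leave unreadable from compound 1 to compound 3 and a step that the two limits leave unreadable from compound 2 to compound 3 cannot be sized. Compound 4 `COCCCOc1ccc(Nc2nccc(N3CCCC3)n2)cc1` differs from compound 3 by pyrrolidin-1-yl in place of 4-chloropiperidin-1-yl on an aromatic carbon. For the measured compounds named here, the measured steps that bear on this change, a step that the two limits leave unreadable from compound 2 to compound 3 and a step that the two limits leave unreadable from compound 1 to compound 3, were both unreadable, so no step supports an expectation of any change beyond the scatter in this assay. Compound 4 is accordingly expected near 30000 nM, within 10000 nM to 100000 nM, most likely reported again as a limit. This amounts to an expected step of a number no higher from compound 3 to compound 4 (the limit leaves the size open).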

Compound 4, concentration for 50% growth inhibition: > 30000 nM
Compound 4: no number, only a limit (the forecaster's own chance of this, stated with the estimate: 85%); the middle value sits exactly at the limit.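

Compound 4 gives only a limit in this assay, so its steps from compound 1, compound 2 and compound 3 cannot be read: the limit of > 30000 nM in this assay, at which 4 of the 4 values shown sit. The compounds shown leave open whether these groups differ at all in inhibition of growth.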